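Ester variation and tolerated concentration on HeLa cells

The source may report more compounds than this note shows. Statements on the series, on what has been measured and on what is new or still open speak of the compounds shown alone.

Measured so far:
compound 1 `Nc1ncnc2c1ncn2CC(O)C(=O)OCCO`: > 400 ug/mL
compound 2 `CCCOC(=O)C(O)Cn1cnc2c(N)ncnc21`: > 400 ug/mL
compound 3 `CC(C)CCOC(=O)C(O)Cn1cnc2c(N)ncnc21`: 400 ug/mL

The read-out is a functional assay on HeLa cells (Homo sapiens) for cytotoxicity; a higher number here means that more compound is tolerated, a lower number that less compound is tolerated. The value of compound 1 is a limit of the assay, not a number. The value of compound 2 is likewise a limit. Among the compounds with values here, compound 3 is the one member of the series with an actual number; the other two entries sit at the limit of > 400 ug/mL in this assay, at which 2 of the 3 values shown sit. The step that the two limits leave unreadable from compound 1 to compound 2 therefore cannot be read. Within the data shown here, the step of a number no higher from compound 1 to compound 3 (the limit leaves the size open) and the step of a number no higher from compound 2 to compound 3 (the limit leaves the size open) show only that compound 3 is no higher than the two limits, with the size left open.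

Compound 4 `CC(C)(C)OC(=O)C(O)Cn1cnc2c(N)ncnc21` differs from compound 3 by tert-butyl in place of isopentyl on an oxygen next to a carbonyl group. Among the measured compounds shown here, none of the measured steps covers this exchange; they show only that ester chains of differing size have given nothing but limits or a value at the limit. No step beyond the scatter is therefore expected in this assay, and compound 4 is estimated at 400 ug/mL, between 200 ug/mL and 800 ug/mL. The expected step of no change at the digits printed from compound 3 to compound 4 (within the scatter) is thus essentially flat, with a fair chance that only a limit is reported.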

Compound 4, minimum cytotoxic concentration: > 400 ug/mL
Compound 4 was reported as a limit (the forecaster's own chance of this, stated with the estimate: 50%); the middle value lies on the limit itself.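

In this assay compound 4 gives > 400 ug/mL, which is a limit of the assay and not a number. On an oxygen next to a carbonyl group, tert-butyl in place of isopentyl is readable only as a number no lower from compound 3 to compound 4 (the limit leaves the size open), which gives this ester position its first step that is open upward rather than downward, while the steps to compound 4 from the other two limit compounds cannot be read. Compound 3 therefore remains the only member of the series with an actual number, and the tert-butyl ester joins the hydroxyethyl and propyl esters at the top of the measurable range: the limit of > 400 ug/mL in this assay, at which 3 of the 4 values shown sit.

Going by these compounds, how far compounds 1, 2 and 4 lie past that limit remains open, so no order among them can be given, and the size of the step to compound 4 is unknown. Also open, on these data alone, is whether a longer chain such as octyl, a benzyl group on the same oxygen, or a free carboxylic acid in place of the ester would give an actual number in this assay.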